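Trifluoromethyl to methoxy on the shared core

This account rests on a few compounds, and the source may have more. Where it says the series, first, only, none or still open, it means among the compounds named here.

Among the measured compounds shown here, in a functional assay on KB cells (Homo sapiens) for antiproliferative activity, read by sulforhodamine B assay, with a stated time of 3 days (on this read-out lower numbers stand for an effect already at smaller amounts and higher numbers for an effect only at larger amounts of compound), compound 3 `CCC1=C(O)c2c(oc(-c3ccccc3C(F)(F)F)cc2=O)C(CC)(CC)C1=O` gives 45.6 uM, the only true number among the three values shown. Compound 1 `CCOc1ccc(-c2cc(=O)c3c(o2)C(CC)(CC)C(=O)C(CC)=C3O)cc1` is reported only as a limit, > 52.4 uM. Compound 2 `CCC1=C(O)c2c(oc(-c3ccc(SC)cc3)cc2=O)C(CC)(CC)C1=O` is likewise reported only as a limit, > 52.1 uM.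

Compound 4 `CCC1=C(O)c2c(oc(-c3ccccc3OC)cc2=O)C(CC)(CC)C1=O` differs from compound 3 at one place, with methoxy in place of trifluoromethyl on an aromatic carbon. The exchange lies ortho to a large group.

One measured step exists in this small set, a step that the two limits leave unreadable from compound 1 to compound 2. It concerns methylsulfanyl in place of ethoxy on an aromatic carbon, so it neither involves the groups exchanged here nor offers a size to carry over. For the measured compounds named here, with no measured step to suggest a shift, the number for compound 3 remains the only anchor, and no change beyond the scatter is expected in this assay. The expected step is a 1.0-fold lower number from compound 3 to compound 4 (0.01 log units; within the scatter). For compound 4 the estimate is 45 uM, with an expected range of 22 uM to 55 uM.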

Compound 4, concentration for half-maximal effect: 40.8 uM
Compound 4: middle estimate off by 1.1-fold (0.04 log units), on the high side, within the range that was stated.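

In this assay, among the compounds shown here, methoxy in place of trifluoromethyl on an aromatic carbon, ortho to a large group, gives the first readable step on the shared core: a 1.1-fold lower number from compound 3 to compound 4 (0.05 log units; within the scatter), so the exchange separates these two compounds by no more than the scatter. 2-Methoxyphenyl in place of 4-(methylsulfanyl)phenyl gives an at least 1.2-fold lower number from compound 2 to compound 4 (0.10 log units; that floor lies within the scatter), which is only a floor because compound 2 is reported as a limit: the limit of > 52.1 uM in this assay, at which 1 of the 4 values shown sits. 2-Methoxyphenyl in place of 4-ethoxyphenyl likewise gives an at least 1.2-fold lower number from compound 1 to compound 4 (0.10 log units; that floor lies within the scatter), again only a floor because compound 1 is reported as a limit: the limit of > 52.4 uM in this assay, at which 1 of the 4 values shown sits.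

As far as these compounds go, the true size of these two steps stays open. Also open, from the compounds shown here alone, is whether an amine or a carboxylic acid at this place would shift the number beyond the scatter.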